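The source may report more compounds than this note shows. Statements on the series, on what has been measured and on what is new or still open speak of the compounds shown alone.

In a functional assay on MGC-803 cells (Homo sapiens) for inhibition, read by sulforhodamine B assay (a lower number here means a stronger inhibitor, a higher number a weaker inhibitor), the measured compounds stand as follows. Compound 1 `COc1ccc(NC2=CC(=O)c3c(nc4n3[C@H]3OC[C@@H](O)[C@H]3OC4)C2=O)cc1` gives 2150 nM. Compound 3 `CCOc1ccc(NC2=CC(=O)c3c(nc4n3[C@H]3OC[C@@H](O)[C@H]3OC4)C2=O)cc1` gives 2090 nM. Compound 2 `O=C1C(N2CCCCC2)=CC(=O)c2c1nc1n2[C@H]2OC[C@@H](O)[C@H]2OC1` gives only a limit of the assay, > 4000 nM.

Compound 3 and compound 1 cannot be told apart here: the step of a 1.0-fold lower number from compound 1 to compound 3 (0.01 log units; within the scatter) lies within the scatter, and the third value is a limit. Compound 4 `O=C1C(NC2CCCC2)=CC(=O)c2c1nc1n2[C@H]2OC[C@@H](O)[C@H]2OC1` differs from compound 3 by cyclopentyl in place of 4-ethoxyphenyl on an amine nitrogen. Going by the values given here, the one measured step that resembles this change is an at least 1.8-fold higher number from compound 1 to compound 2 (0.26 log units; that floor lies within the scatter), where a saturated ring also replaced an aromatic one; its floor is set by the limit of > 4000 nM in this assay, at which 1 of the 3 values shown sits. Compound 4 keeps the amine hydrogen, so a weaker shift is expected: a 1.9-fold higher number from compound 3 to compound 4 (0.28 log units; within the scatter). Compound 4 is estimated at 4000 nM, between 1500 nM and 12000 nM.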

Compound 4, half-maximal inhibitory concentration: > 16000 nM
Compound 4 was reported as a limit (the forecaster's own chance of this, stated with the estimate: 45%); middle value at least 4.0-fold (0.60 log units) away from the limit.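

At the amine nitrogen, swapping the aromatic ring for cyclopentyl gives an at least 7.6-fold higher number from compound 3 to compound 4 (0.88 log units; beyond the scatter), and the matching change from the methoxy compound gives an at least 7.4-fold higher number from compound 1 to compound 4 (0.87 log units; beyond the scatter). Both steps lie beyond the scatter, which the earlier step to compound 2 did not, and compound 4 keeps the amine hydrogen, so that hydrogen alone does not preserve the activity of compound 1 and compound 3. The value of compound 4 is a limit: the limit of > 16000 nM in this assay, at which 1 of the 4 values shown sits.

The step between compound 2 and compound 4 cannot be read. As far as these compounds go, whether a benzyl group or an unsubstituted phenyl on this nitrogen would match compound 3 remains open.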